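Trimming the Cyclopropylmethyl Group to a Cyclopropyl Ring

The source may hold more compounds than are shown below. What is called first, only, known or untested is meant among the compounds shown, and "the series" means these compounds.

Compound 3 `c1nc(NC2CC2)c2ncn(CC3CC3)c2n1` gives 4 mg/kg in a functional assay on the whole organism for antagonist activity, with Rattus norvegicus as the target (on this read-out lower numbers stand for an effect already at smaller amounts and higher numbers for an effect only at larger amounts of compound), the lowest of the three numbers here. Compound 1 `CN(C)c1ncnc2c1ncn2CC1CC1` gives 4.5 mg/kg, and the step of a 1.1-fold lower number from compound 1 to compound 3 (0.05 log units; within the scatter) lies within the scatter, so these two cannot be ordered. Compound 2 `Nc1ncnc2c1ncn2CC1CC1` gives 20 mg/kg, and a 5.0-fold lower number from compound 2 to compound 3 (0.70 log units; beyond the scatter) is beyond the scatter. Compound 4 `c1nc(NC2CC2)c2ncn(C3CC3)c2n1` differs from compound 3 only by cyclopropyl in place of cyclopropylmethyl on an aromatic nitrogen. Within the data shown here, every measured step here alters the amino group on an aromatic carbon, as in a 4.4-fold higher number from compound 1 to compound 2 (0.65 log units; beyond the scatter), or a hydrogen on that nitrogen; none alters the group on the ring nitrogen, so no measured step bears on this change. For compound 4 the expected step is therefore a 1.5-fold higher number from compound 3 to compound 4 (0.18 log units; within the scatter), within the scatter. The estimate for compound 4 is 6 mg/kg, in a range from 2 mg/kg to 20 mg/kg.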

Compound 4, dose for half-maximal effect: 4.5 mg/kg
For compound 4 the middle estimate is 1.3-fold (0.12 log units) above the measured one; the range from low to high includes it.
By their numbers in this assay, from the lowest: compounds 3, 1 and 4 (each within the scatter of the next); then compound 2.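

Among these compounds, the earlier steps all altered the amino group on an aromatic carbon, so this is the first look at the group on the ring nitrogen. Cyclopropyl in place of cyclopropylmethyl gives a 1.1-fold higher number from compound 3 to compound 4 (0.05 log units; within the scatter) in this assay, so the two groups cannot be told apart at this position. Nothing measured here offers a reason for this result.

Still open, going by these compounds, is whether a longer chain, an amine or a carboxylic acid on that ring nitrogen would give a similar number. On these data alone, a plain hydrogen there is equally open.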